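This account rests on a few compounds, and the source may have more. Where it says the series, first, only, none or still open, it means among the compounds named here.

Compound 1 `COc1ccccc1/C=C/C(=O)/C=C/c1nc(C)c(C)nc1C` and compound 2 `COc1ccc(/C=C/C(=O)/C=C/c2nc(C)c(C)nc2C)cc1` share one core and have both been tested in a functional assay on A549/CDDP cells (Homo sapiens) for antiproliferative activity, read by MTT assay, with a stated time of 72 h; a lower number here means a stronger inhibitor, a higher number a weaker inhibitor. In this test, compound 1 gives 4740 nM and compound 2 gives 3610 nM. These two numbers lie within the usual scatter of each other, so compound 2 stands level with compound 1 and the data do not separate them.

The next compound, compound 3 `COc1ccc(/C=C/C(=O)/C=C/c2nc(C)c(C)nc2C)c(OC)c1`, is built from compound 2 by one structural change: methoxy in place of hydrogen on an aromatic carbon. Put simply, a methoxy takes the place of hydrogen on an aromatic carbon. Among the compounds with values here, no measured pair of compounds differs in only one place, so the data do not show directly what such a change does in this assay. Within the data shown here, with compound 1 at 4740 nM and compound 2 at 3610 nM, the only guide is this narrow spread of values, so no step beyond the scatter is expected in either direction. The expected change is a 1.2-fold lower number from compound 2 to compound 3 (0.08 log units; within the scatter). For compound 3, the estimated value is 3000 nM, with an expected range from 1200 nM to 7000 nM.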

Compound 3, half-maximal inhibitory concentration: 2850 nM
Estimate against measurement, compound 3: 1.1-fold (0.02 log units) above; the range from low to high includes it.
By their numbers in this assay, from the lowest: compounds 3, 2 and 1 (each within the scatter of the next).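

Within the data shown here, this is the first direct reading of methoxy in place of hydrogen on an aromatic carbon in this assay: at the place ortho to a large group and meta to a methoxy group, the change gives a 1.3-fold lower number from compound 2 to compound 3 (0.10 log units; within the scatter) and so leaves compound 3 level with its parent. The same kind of change can also be read at the other place on the ring, where it gives a 1.7-fold lower number from compound 1 to compound 3 (0.22 log units; within the scatter) and likewise does not separate the two compounds. Whichever of the two methoxy groups of compound 3 is counted as the added one, the step stays within the scatter, and no measurement shown here offers an explanation for this result.

From the compounds shown here alone, what a group other than methoxy would do at the place ortho to a large group, such as an amine, a carboxylic acid or a longer chain, remains open, as does whether any group there gives a step beyond the scatter. Going by these compounds, all three compounds carry at least one methoxy on this ring, so the effect of the first methoxy, set against a ring with hydrogen alone, also remains open.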